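This account rests on a few compounds, and the source may have more. Where it says the series, first, only, none or still open, it means among the compounds named here.

Compound 3 `CCCCCNC(=O)CC1CCc2cc(OC)c(OC)cc21` carries a pentyl chain on its amide nitrogen and, in a functional assay on the whole organism (strain Wistar) for inhibition, with Rattus norvegicus as the target, read by paw edema, with stated times of 60 min and 24 h, at a dose of 100 mg/kg by the oral route (on this read-out lower numbers stand for less inhibition and higher numbers for more inhibition at the one dose given (going by the name of the read-out)), compound 3 gives 46.7%, the highest of the three numbers measured. Compound 1 `CNC(=O)CC1CCc2cc(OC)c(OC)cc21`, with only a methyl on that nitrogen, gives 33.3%, and compound 2 `CCCNC(=O)CC1CCc2cc(OC)c(OC)cc21`, with a propyl, gives 26.7%. Lengthening the chain read as a number 13.4 percentage points higher from compound 1 to compound 3 (beyond the scatter) and a number 20 percentage points higher from compound 2 to compound 3 (beyond the scatter), while the shorter step a number 6.6 percentage points lower from compound 1 to compound 2 (within the scatter) was within the scatter, so only the longest chain stood apart.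

Compound 4 `COc1cc2c(cc1OC)C(CC(=O)NC1CCCCC1)CC2` takes the next step: cyclohexyl in place of pentyl on an amide-type nitrogen. Within the data shown here, no measured pair shows a ring replacing a chain on this nitrogen, so the earlier steps bear on it only loosely: they suggest a bulkier group at this position does not lower the read-out. The expected change is therefore small, a number 1.7 percentage points lower from compound 3 to compound 4 (within the scatter), lying within the scatter in either direction. For compound 4 the estimate in this assay is 45%, with a range from 28% to 62%.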

Compound 4, a percentage reported as inhibition, in the whole organism at one dose (the size of the read-out at that dose, not a potency): 53.3%
Estimate against measurement, compound 4: 8.3 percentage points below, within the range that was stated.
By their numbers in this assay, from the lowest: compounds 2 and 1 (each within the scatter of the next); then compounds 3 and 4 (each within the scatter of the next).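

In this assay, a ring can stand on this nitrogen in place of a chain with no reading beyond the usual scatter: cyclohexyl in place of pentyl gives a number 6.6 percentage points higher from compound 3 to compound 4 (within the scatter) and leaves compound 3 and compound 4 level. Cyclohexyl also stands clear of both shorter chains, with a number 26.6 percentage points higher from compound 2 to compound 4 (beyond the scatter) and a number 20 percentage points higher from compound 1 to compound 4 (beyond the scatter) as its two steps, so the upper level seen so far does not depend on an open chain. Nothing at hand explains these differences.

The compounds shown do not tell how phenyl, cyclopentyl or a chain longer than pentyl would read on this amide-type nitrogen. Going by these compounds, every compound here also keeps the amide hydrogen, so the effect of replacing it with a methyl group remains open as well.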